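Acid to ethyl ester on the shared core

A few compounds are considered here, and "the series" means these few. Any claim that something is new, unique, unknown or untested is made for them only; others in the source may bear on it.

Compound 1 `O=C(O)CSc1nc(Cl)cc(Nc2cccc3c2CCC3)n1` stands at the higher of the two measured numbers in an assay for inhibition of Polyunsaturated fatty acid 5-lipoxygenase (Homo sapiens), tested at 1 uM; on this read-out higher numbers stand for a weaker effect at the one concentration tested and lower numbers for a stronger effect: compound 1 gives 71.1%. Going by the values given here, the only other measured member, compound 2 `CCOC(=O)C(Sc1nc(Cl)cc(Nc2ccc3ncccc3c2)n1)c1ccccc1`, carries an ethyl ester and a different amine portion; in this assay compound 2 gives 52.7%, a number beyond the scatter below that of compound 1. Among the compounds with values here, as the two structures differ in more than one place, this pair yields no single step.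

Compound 3 `CCOC(=O)CSc1nc(Cl)cc(Nc2cccc3c2CCC3)n1` is the ethyl ester of compound 1. The difference is ethyl in place of hydrogen on an oxygen next to a carbonyl group. Within the data shown here, no measured pair isolates this change, so the expectation leans on the lower number of compound 2 only loosely. In this assay a modest move toward a lower number is expected, roughly at the edge of the scatter, a number 11.1 percentage points lower from compound 1 to compound 3 (beyond the scatter). Compound 3 is therefore estimated at 60%, within a range from 40% to 80%.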

Compound 3, a percentage reported as activity, at one concentration (the size of the read-out at that concentration, not a potency): 65.2%
For compound 3 the middle estimate is 5.2 percentage points below the measured one; the range from low to high includes it.
By their numbers in this assay, from the lowest: compound 2; then compounds 3 and 1 (each within the scatter of the next).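

In this assay, going by these compounds alone, ethyl in place of hydrogen on an oxygen next to a carbonyl group gives a number 5.9 percentage points lower from compound 1 to compound 3 (within the scatter), the first single-place step. On the core of compound 1, carboxy to ethoxycarbonyl therefore leaves the read-out within the scatter, so at this one concentration the free acid and its ethyl ester cannot be told apart. No accompanying measurement speaks to the reason for this result.

As far as these compounds go, whether a methyl ester, an isopropyl ester or a primary amide at this position would separate from compound 1 and compound 3 remains open, as does the effect of a longer chain between the sulfur and the carbonyl. Also open, from the compounds shown here alone, is whether the same change would read alike with the amine portion of compound 2.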